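Amine side chain: from compound 2 to compound 3

The compounds below may be only part of what the source reports. "The series", "measured", "known", "first", "only" and "open" are said of these compounds alone.

Measured so far:
compound 1 `CC(C)(CC(=O)N[C@@H]1CCc2ccccc2N(Cc2ccc(-c3ccccc3-c3nn[nH]n3)cc2)C1=O)NCCO` gives 30 nM
compound 2 `CC(C)(CC(=O)N[C@@H]1CCc2ccccc2N(Cc2ccc(-c3ccccc3-c3nn[nH]n3)cc2)C1=O)NC[C@H](O)[C@@H](O)CO` gives 40 nM

In a functional assay (Pituitary gland cell) with Rattus norvegicus as the target (on this read-out lower numbers stand for an effect already at smaller amounts and higher numbers for an effect only at larger amounts of compound), compound 2 stands at 40 nM and compound 1 at 30 nM in the same range, so no order can be drawn between them. Compound 3 `CO[C@H](C)CNC(C)(C)CC(=O)N[C@@H]1CCc2ccccc2N(Cc2ccc(-c3ccccc3-c3nn[nH]n3)cc2)C1=O` is still unmeasured. Its difference from compound 2 is 1-methoxyethyl in place of 1,2,3-trihydroxypropyl on a saturated chain carbon bound to an amine nitrogen and amounts to 1-methoxyethyl in place of 1,2,3-trihydroxypropyl. For the measured compounds named here, only one measured step bears on this, a 1.3-fold higher number from compound 1 to compound 2 (0.12 log units; within the scatter) on the same side chain, where 1,2-dihydroxyethyl took the place of hydrogen, so no step beyond the scatter is expected in this assay in either direction. Going by the values given here, no measured compound carries a methoxy group, and a single step is a thin guide, so the range is kept wide. The estimated step is no change at the digits printed from compound 2 to compound 3 (within the scatter) and remains an expectation only. Compound 3 is estimated at 40 nM with an expected range of 15 nM to 110 nM in this read-out.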

Compound 3, concentration for half-maximal effect: 20 nM
Estimate against measurement, compound 3: 2.0-fold (0.30 log units) above; measured number inside the range.
By their numbers in this assay, from the lowest: compounds 3, 1 and 2 (each within the scatter of the next).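

In this assay, the side chain on the amine nitrogen gives no sign of depending on its hydroxyl groups: 1-methoxyethyl in place of 1,2,3-trihydroxypropyl, which takes the group from 3 hydrogen-bond donors to 0 and from 6 heavy atoms to 4, gives a 2.0-fold lower number from compound 2 to compound 3 (0.30 log units; within the scatter). The comparison with the smaller hydroxyl-bearing chain reads the same way, with 1-methoxyethyl in place of hydroxymethyl giving a 1.5-fold lower number from compound 1 to compound 3 (0.18 log units; within the scatter), so the series now spans chains with and without a free hydroxyl, and all three compounds remain within the scatter of one another on this read-out. No supporting measurement is available to account for this flat response at the position.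

On these data alone, it remains open whether any oxygen is needed on this chain, as a plain propyl or isobutyl group would show, and whether a carboxylic acid or a second amine at the same place would leave the number just as unmoved. Also open, as far as these compounds go, is whether the defined stereocentre of the 1-methoxyethyl group matters, which only its mirror-image configuration could settle.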